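Compound 3 to compound 4: moving the pyridine attachment

The compounds below may be only part of what the source reports. "The series", "measured", "known", "first", "only" and "open" are said of these compounds alone.

Values in an ADME assay on microsomes from liver (Mus musculus) for metabolic stability, read by LC-MS, using NADPH, tested at 4.6 uM; on this read-out higher numbers stand for a longer-lived compound and lower numbers for a shorter-lived compound:
- compound 1 `O=C(NCCCCc1ccccc1)n1cc(-c2ccc(F)cc2)oc1=O`: 1 h
- compound 2 `COc1cc(-c2cn(C(=O)NCCCCc3ccccc3)c(=O)o2)ccc1F`: > 1 h (a limit)
- compound 3 `O=C(NCCCCc1ccccc1)n1cc(-c2cccnc2)oc1=O`: > 1 h (a limit)

Compound 3 stands at > 1 h, a limit and not a number. Much of the series rests on (the limit of > 1 h in this assay, at which 2 of the 3 values shown sit).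

Compound 4 `O=C(NCCCCc1ccccc1)n1cc(-c2ccncc2)oc1=O` carries pyridin-4-yl in place of pyridin-3-yl, on an aromatic carbon next to the ring oxygen: pyridin-4-yl in place of pyridin-3-yl on an aromatic carbon.

The nearest measured step, a number no lower from compound 1 to compound 3 (the limit leaves the size open), has no readable size. Neither have a number no lower from compound 1 to compound 2 (the limit leaves the size open) and a step that the two limits leave unreadable from compound 2 to compound 3. Among the compounds with values here, no measured step joins two pyridine isomers.

Resting on a number no lower from compound 1 to compound 3 (the limit leaves the size open), no change beyond the scatter is expected in this assay, and the expected step is a step that the limit leaves unreadable from compound 3 to compound 4.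

Compound 4 is estimated at 1.2 h, with an expected range of 0.6 h to 2.4 h.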

Compound 4, half-life: > 1 h
Compound 4: a limit, no number; the forecaster's own chance of this, stated with the estimate: 60%; the middle value does not contradict the limit.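

In this assay compound 4 gives > 1 h as a limit and not a number. Only a number no lower from compound 1 to compound 4 (the limit leaves the size open) has a direction. The steps joining compound 4 to compound 1, compound 2 and compound 3 have no readable size, so pyridin-4-yl and pyridin-3-yl cannot be ranked at this position. A second pyridine isomer on this aromatic carbon ends at the same ceiling: the limit of > 1 h in this assay, at which 3 of the 4 values shown sit.

How far any of these compounds lies past that limit stays open. So does the half-life with an amine or a carboxylic acid on this aromatic carbon.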